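Dimethylamino for hydroxy on the biaryl ester

The compounds below may be only part of what the source reports. "The series", "measured", "known", "first", "only" and "open" are said of these compounds alone.

Compound 1, `CCOC(=O)c1ccnc(-c2ccc(OCC)cc2)c1`: 87%
Compound 2, `CCOC(=O)c1cccc(-c2ccc(O)cc2)c1`: 77%

Of the compounds shown here, two have been measured in an assay on COS-7 cells for inhibition of patatin-like phospholipase domain-containing protein 2 (Mus musculus), tested at 200 uM; on this read-out higher numbers stand for more inhibition at the one concentration tested (going by the name of the read-out) and lower numbers for less inhibition. Compound 1 gives 87% in this assay, and compound 2 gives 77%. For the measured compounds named here, these two numbers lie within the usual scatter of each other, so compound 2 stands at the same level as compound 1 on what has been measured, and no step between the two can be drawn, since they differ in more than one place.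

Compound 3, `CCOC(=O)c1cccc(-c2ccc(N(C)C)cc2)c1`, has not yet been measured. It differs from compound 2 as follows: dimethylamino in place of hydroxy on an aromatic carbon. Going by the values given here, no step between measured compounds shows what such a change does here, so the expected step of a number 2 percentage points lower from compound 2 to compound 3 (within the scatter) in this assay is small, with no clear direction beyond the scatter. Compound 3 is therefore estimated to give 75% in this assay, with a range from 55% to 90%.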

Compound 3, a percentage reported as inhibition, at one concentration (the size of the read-out at that concentration, not a potency): 87%
Beside the measured number, compound 3's estimate is 12 percentage points below it, within the range that was stated.
By their numbers in this assay, from the lowest: compounds 2, 1 and 3 (each within the scatter of the next).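

In this assay, for the compounds shown here, dimethylamino in place of hydroxy on an aromatic carbon, para to a large group, gives a number 10 percentage points higher from compound 2 to compound 3 (within the scatter) and is the only step read so far at this position. It shows that compound 3 stands at the same level as compound 2 without the hydroxy and its hydrogen-bond donor, and with a group of 3 heavy atoms in place of 1. Nothing available bears on why this change leaves the read-out at that level.

Going by these compounds, whether a smaller amine, a methoxy group or a carboxylic acid would hold the same level on this aromatic carbon remains open. Since each number comes from a single concentration, the compounds shown also leave open whether compound 2 and compound 3 match in potency.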